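Thiophen-2-yl to 3-Nitrophenyl on a Shared Core

A few compounds are considered here, and "the series" means these few. Any claim that something is new, unique, unknown or untested is made for them only; others in the source may bear on it.

Two compounds have been measured in a functional assay on ECa-109 cells (Homo sapiens) for cytotoxicity, read by MTT assay, with a stated time of 48 h; a higher number here means a weaker inhibitor, a lower number a stronger inhibitor:

compound 1 `COc1ccc(C(C2=C(O)C(=O)c3ccccc3C2=O)c2c[nH]c3ccccc23)cc1Br`: 11800 nM
compound 2 `O=C1C(O)=C(C(c2cccs2)c2c[nH]c3ccccc23)C(=O)c2ccccc21`: 12100 nM

Compound 2 has the higher of the two numbers, and its nearest neighbour is compound 1, which differs only in the group on a saturated chain carbon bound to an aromatic carbon and a double-bonded ring carbon; the step of a 1.0-fold higher number from compound 1 to compound 2 (0.01 log units; within the scatter) lies within the scatter, so the two read as equal.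

Compound 3 `O=C1C(O)=C(C(c2cccc([N+](=O)[O-])c2)c2c[nH]c3ccccc23)C(=O)c2ccccc21` has not yet been measured. It differs from compound 2 by 3-nitrophenyl in place of thiophen-2-yl on a saturated chain carbon bound to an aromatic carbon and a double-bonded ring carbon. Among the compounds with values here, the only step that bears on this change is the one from compound 1 to compound 2, which exchanged a group at the same place and gave no movement beyond the scatter. With so little to go on, compound 3 is expected to give a step of a 1.0-fold lower number from compound 2 to compound 3 (0.00 log units; within the scatter) in this assay , that is, no change beyond the scatter. Compound 3 is estimated at 12000 nM, with a range from 5000 nM to 30000 nM.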

Compound 3, half-maximal inhibitory concentration: 36200 nM
Compound 3: the middle estimate sits 3.0-fold (0.48 log units) below what was measured, and the stated range ends below it.
By their numbers in this assay, from the lowest: compounds 1 and 2 (each within the scatter of the next); then compound 3.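

This position is not indifferent to the group it carries in this assay: putting 3-nitrophenyl there weakens the result against both earlier groups (a 3.0-fold higher number from compound 2 to compound 3 (0.48 log units; beyond the scatter) and a 3.1-fold higher number from compound 1 to compound 3 (0.49 log units; beyond the scatter)). The equal readings of compound 1 and compound 2 had shown only that thiophen-2-yl and 3-bromo-4-methoxyphenyl can be exchanged without a change beyond the scatter, and that tolerance does not extend to every aromatic group, though the loss here is modest. Nothing measured here explains why this exchange weakens the result.

The compounds shown cannot separate the part played by the nitro group from that of the phenyl ring carrying it. An unsubstituted phenyl, or an amine in place of the nitro group on the same ring, would help to tell these apart.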